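A few compounds are considered here, and "the series" means these few. Any claim that something is new, unique, unknown or untested is made for them only; others in the source may bear on it.

Of the compounds shown here, three sharing one core have been measured in an assay on HEK293 cells for agonist activity at Toll-like receptor 2 (Homo sapiens); a higher number here means that more compound is needed for the effect, a lower number that less compound is needed. Compound 1 `CCCCCCCCCCCC(=O)OC[C@H](CSC[C@@H](N)C(=O)NCCOCCOS(=O)(=O)O)OC(=O)CCCCCCCCCCC` gives 61 nM. Compound 2 `CCCCCCCCCCCC(=O)OC[C@H](CSC[C@@H](N)C(=O)NC(C)c1ccc(O)cc1)OC(=O)CCCCCCCCCCC` gives 2890 nM. Compound 3 `CCCCCCCCCCCC(=O)OC[C@H](CSC[C@@H](N)C(=O)NCCCCCC(=O)O)OC(=O)CCCCCCCCCCC` gives 108 nM. Among these three numbers compound 3 stands second highest: its nearest neighbour is compound 1, the step of a 1.8-fold higher number from compound 1 to compound 3 (0.25 log units; within the scatter) lying within the scatter, while its furthest is compound 2, with a 27-fold lower number from compound 2 to compound 3 (1.43 log units; beyond the scatter). The other large movement in the set, a 47-fold higher number from compound 1 to compound 2 (1.68 log units; beyond the scatter), shows the same thing from the opposite side.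

The next compound, compound 4 `CCCCCCCCCCCC(=O)OC[C@H](CSC[C@@H](N)C(=O)NCCCCN)OC(=O)CCCCCCCCCCC`, differs from compound 3 in one place: amino in place of carboxymethyl on a saturated chain carbon, four bonds along the chain from an amide-type nitrogen. The step that bears most directly on this change is a 1.8-fold higher number from compound 1 to compound 3 (0.25 log units; within the scatter), where one polar group at the end of the chain was exchanged for another and the number barely moved. The large steps both involve the 1-(4-hydroxyphenyl)ethyl group of compound 2 and do not resemble the present change. He therefore expects for compound 4 in this assay a step of about a 1.1-fold lower number from compound 3 to compound 4 (0.03 log units; within the scatter), that is, nothing beyond the scatter. His estimate for compound 4 is 100 nM, with a range from 30 nM to 400 nM.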

Compound 4, half-maximal effective concentration: 1040 nM
The estimate for compound 4 lay 10-fold (1.02 log units) below the measured number, outside the stated range (above it).
By their numbers in this assay, from the lowest: compounds 1 and 3 (each within the scatter of the next); then compound 4; then compound 2.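

In this assay the end of the chain on the amide-type nitrogen turns out to matter: amino in place of carboxymethyl gives a 9.6-fold higher number from compound 3 to compound 4 (0.98 log units; beyond the scatter) and so breaks the closeness seen between the carboxylic acid and the sulfooxy ends. Measured against the 2-(2-(sulfooxy)ethoxy)ethyl group, the 4-aminobutyl group gives a 17-fold higher number from compound 1 to compound 4 (1.23 log units; beyond the scatter) while against the 1-(4-hydroxyphenyl)ethyl group it gives a 2.8-fold lower number from compound 2 to compound 4 (0.44 log units; beyond the scatter) and thus takes a middle place, with a printed step beyond the scatter on either side. No measurement at hand accounts for this difference between the amine and the two acidic ends.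

The change from compound 3 to compound 4 alters the end group and the length of the chain together, so the step cannot say how much belongs to each; a 5-aminopentyl chain or a 4-carboxybutyl chain on the shared core would separate the two. From the compounds shown here alone, whether a tertiary amine or a primary amide at the chain end would stand with the amino group or with the carboxylic acid also remains open.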